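Demethylation at the hydroxyurea-bearing carbon in the alkyne series

The source may report more compounds than this note shows. Statements on the series, on what has been measured and on what is new or still open speak of the compounds shown alone.

Measured so far:
compound 1 `C[C@@H](C#Cc1cccc(C(=O)NCc2ccccc2C(F)(F)F)c1)N(O)C(N)=O` — 700 nM
compound 2 `C[C@H](C#Cc1cccc(C(=O)NCc2ccccc2C(F)(F)F)c1)N(O)C(N)=O` — 600 nM

Among the compounds with values here, compound 2 has the lowest of the two numbers so far in an assay for inhibition of Polyunsaturated fatty acid 5-lipoxygenase (Homo sapiens), read by HPLC, with stated times of 15 min and 10 min; a lower number here means a stronger inhibitor, a higher number a weaker inhibitor; its nearest neighbour is compound 1, and the step of a 1.2-fold lower number from compound 1 to compound 2 (0.07 log units; within the scatter) leaves the pair within the scatter, the two being related only by the fact that compounds 1 and 2 differ only in the configuration as drawn. Compound 3 `NC(=O)N(O)CC#Cc1cccc(C(=O)NCc2ccccc2C(F)(F)F)c1` is not yet measured in this assay. It differs from compound 2 by hydrogen in place of methyl on a saturated chain carbon bound to an amide-type nitrogen and a triple-bonded carbon, which also removes the stereocentre that separates compound 1 from compound 2. Within the data shown here, the only measured step concerns that stereocentre, and it was within the scatter; no measured step tests loss of the methyl itself. The expected step of a 1.7-fold higher number from compound 2 to compound 3 (0.22 log units; within the scatter) is therefore set small, with wide bounds. For compound 3 the estimate in this assay is 1000 nM, expected between 350 nM and 3500 nM.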

Compound 3, half-maximal inhibitory concentration: 4000 nM
Beside the measured number, compound 3's estimate is 4.0-fold (0.60 log units) below it; the measured number lies above the stated range.
By their numbers in this assay, from the lowest: compounds 2 and 1 (each within the scatter of the next); then compound 3.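

In this assay the methyl on the saturated chain carbon bound to an amide-type nitrogen and a triple-bonded carbon proves to matter, although its drawn configuration did not separate compounds: replacing it with hydrogen gives a 6.7-fold higher number from compound 2 to compound 3 (0.82 log units; beyond the scatter) and a 5.7-fold higher number from compound 1 to compound 3 (0.76 log units; beyond the scatter). Both steps lie beyond the scatter, so the weakening appears from either methyl compound, and those two are related in one way only: the fact that compounds 1 and 2 differ only in the configuration as drawn. The change from 3-(carbamoyl(hydroxy)amino)but-1-yn-1-yl to 3-(carbamoyl(hydroxy)amino)prop-1-yn-1-yl therefore weakens inhibition with the loss of one carbon.

On these data alone, whether methyl is the best group at this carbon remains open, since an ethyl, a cyclopropyl or a second methyl there could lower the number further or raise it. The compounds shown also give no reason for the step, and the effect rests on this single hydrogen compound.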